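Reshaping compound 1 into compound 4

A few compounds are considered here, and "the series" means these few. Any claim that something is new, unique, unknown or untested is made for them only; others in the source may bear on it.

- Compound 1 `c1ccc2c(c1)CC2CCCN1CCN(c2cccc3c2OCCO3)CC1` gives 0.18 mg/kg
- Compound 2 `c1ccc2c(c1)CC2CCCCN1CCN(c2cccc3c2OCCO3)CC1` gives 1.43 mg/kg
- Compound 3 `c1ccc2c(c1)CCC2CN1CCN(c2cccc3c2OCCO3)CC1` gives 1.32 mg/kg

In a functional assay on the whole organism for antagonist activity, with Rattus norvegicus as the target (a lower number here means that less compound is needed, a higher number that more compound is needed for the effect), compound 1 holds the lowest of the three numbers, and both other compounds lie beyond the scatter from it. Compound 4 `c1ccc2c(c1)CCC2CCN1CCN(c2cccc3c2OCCO3)CC1` has not yet been measured. It has the same atoms as compound 1, joined differently: a group of 9 heavy atoms (9 carbon; one five-membered non-aromatic ring of carbon only, one six-membered aromatic ring of carbon only) in place of a group of 9 heavy atoms (9 carbon; one four-membered non-aromatic ring of carbon only, one six-membered aromatic ring of carbon only), on a saturated chain carbon, two bonds along the chain from an amine nitrogen in a ring. The entering group is 2,3-dihydro-1H-inden-1-yl.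

Going by the values given here, only one measured step starts from compound 1, and it bears on this change only indirectly: a 7.9-fold higher number from compound 1 to compound 2 (0.90 log units; beyond the scatter). That step is modest, and it also alters the group on the chain. Compound 3 likewise stands higher than compound 1. Compound 3 gives 1.32 mg/kg. Among the compounds with values here, no measured compound therefore improves on compound 1, so a modest rise in this assay is expected rather than a fall. Within the data shown here, the expected change is a 3.1-fold higher number from compound 1 to compound 4 (0.49 log units; beyond the scatter), somewhat smaller than the one measured step. The estimate for compound 4 is 0.55 mg/kg, with an expected range from 0.17 mg/kg to 1.8 mg/kg.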

Compound 4, dose for 50% inhibition: 1.29 mg/kg
Compound 4: middle estimate off by 2.3-fold (0.37 log units), on the low side; the measured number falls inside the stated range.
By their numbers in this assay, from the lowest: compound 1; then compounds 4, 3 and 2 (each within the scatter of the next).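

In this assay, putting 2,3-dihydro-1H-inden-1-yl in place of the group with the four-membered ring, on a saturated chain carbon two bonds along the chain from an amine nitrogen in a ring, gives a 7.2-fold higher number from compound 1 to compound 4 (0.86 log units; beyond the scatter). The earlier step added a carbon to the group, whereas here the count of heavy atoms stays the same, so a rearrangement of the same atoms alone is enough to carry a step beyond the scatter, and compound 1 stays lowest of the four. Nothing measured here explains this step.

The compounds shown leave open how a six-membered non-aromatic carbon ring in this group would read in this assay. They also leave open whether a longer chain carrying 2,3-dihydro-1H-inden-1-yl would bring the number back towards that of compound 1.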